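Methyl-to-chloro swap on the anilino ring, fluoro core

This account rests on a few compounds, and the source may have more. Where it says the series, first, only, none or still open, it means among the compounds named here.

Compound 1 `CCn1c(=O)/c(=C2\Sc3ccc(C)cc3N2C)s/c1=C\c1ccncc1Nc1ccccc1Cl` and compound 2 `CCn1c(=O)/c(=C2\Sc3ccc(C)cc3N2C)s/c1=C\c1ccncc1Nc1ccccc1C` share one core; in a functional assay on CWR22R cells (Homo sapiens) for inhibition (on this read-out higher numbers stand for weaker inhibition and lower numbers for stronger inhibition), compound 1 gives 350 nM and compound 2 gives 480 nM. The change between them, (chloro in place of methyl on an aromatic carbon), made the step of a 1.4-fold lower number from compound 2 to compound 1 (0.14 log units; within the scatter). Compound 3 `CCn1c(=O)/c(=C2\Sc3cc(F)ccc3N2C)s/c1=C\c1ccncc1Nc1ccccc1C` carries a different core, and the difference between the two cores is not broken down here; in this assay compound 3 gives 2300 nM, the highest of the three numbers. Compound 4 `CCn1c(=O)/c(=C2\Sc3cc(F)ccc3N2C)s/c1=C\c1ccncc1Nc1ccccc1Cl` is the counterpart of compound 3 with the same change, (chloro in place of methyl on an aromatic carbon), that took compound 2 to compound 1. Because that earlier step was a 1.4-fold lower number from compound 2 to compound 1 (0.14 log units; within the scatter), the step from compound 3 to compound 4 is expected to be similarly small, a 1.4-fold lower number from compound 3 to compound 4 (0.13 log units; within the scatter). Compound 4 is therefore estimated at 1700 nM, with a range of 800 nM to 3500 nM.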

Compound 4, half-maximal inhibitory concentration: 490 nM
The estimate for compound 4 lay 3.5-fold (0.54 log units) above the measured number; measured number below the stated range.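

The change from (2-methylphenyl)amino to (2-chlorophenyl)amino does not carry over from one core to the other at a single size in this assay: the same change on two cores in this assay, a 1.4-fold lower number (0.14 log units; within the scatter) from compound 2 to compound 1 and a 4.7-fold lower number (0.67 log units; beyond the scatter) from compound 3 to compound 4, 3.4-fold (0.53 log units) apart, beyond the scatter of two such steps

The step on the fluoro core is a 4.7-fold lower number from compound 3 to compound 4 (0.67 log units; beyond the scatter), while the step on the core of compound 1 stays within the scatter, so a step read on one of these cores was a poor guide to the other. These two pairs show that the size of the change depends on the core, but they give no reason for this and do not say how the change would behave on any further core.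

Open, going by these compounds, is how a methoxy, nitrile or trifluoromethyl group on the same aromatic carbon would behave on either core. Also open, on these data alone, is whether the gap between the cores would persist with such groups.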